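A few compounds are considered here, and "the series" means these few. Any claim that something is new, unique, unknown or untested is made for them only; others in the source may bear on it.

Measured so far: compound 1 `COc1ccc(-c2cc3ccccc3nc2/C=C/C(=O)c2c(OC)cccc2OC)cc1`, compound 2 `COc1ccc(-c2cc3ccccc3nc2/C=C/C(=O)c2ccc(OC)c(OC)c2)cc1` and compound 3 `COc1ccc(-c2cc3ccccc3nc2/C=C/C(=O)c2ccc([N+](=O)[O-])cc2)cc1`.

In a functional assay on MCF7 cells (Homo sapiens) for antiproliferative activity, read by XTT assay, with a stated time of 72 h (on this read-out higher numbers stand for weaker inhibition and lower numbers for stronger inhibition), compound 1 gives 4520 nM. Compound 2 gives 6030 nM in this assay. Compound 3 gives 4110 nM in this assay. Compound 2 thus carries the highest of the three numbers, though every pair lies within the scatter of one another.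

Compound 4 `COc1ccc(-c2cc3ccccc3nc2/C=C/C(=O)c2ccsc2)cc1` is not yet measured. It differs from compound 2 by thiophen-3-yl in place of 3,4-dimethoxyphenyl on a carbonyl carbon. All three measured steps replace the ring on the carbonyl carbon, and each stayed within the scatter: a 1.3-fold higher number from compound 1 to compound 2 (0.13 log units; within the scatter), a 1.1-fold lower number from compound 1 to compound 3 (0.04 log units; within the scatter) and a 1.5-fold lower number from compound 2 to compound 3 (0.17 log units; within the scatter). On this basis compound 4 is expected to show no step beyond the scatter, a 1.1-fold lower number from compound 2 to compound 4 (0.04 log units; within the scatter). The estimated value of compound 4 is 5500 nM, with a range from 2500 nM to 12000 nM.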

Compound 4, half-maximal inhibitory concentration: 6010 nM
Compound 4: middle estimate off by 1.1-fold (0.04 log units), on the low side, and the stated range covers the measured number.
By their numbers in this assay, from the lowest: compounds 3, 1, 4 and 2 (each within the scatter of the next).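

Replacing the aryl groups on the carbonyl carbon with thiophen-3-yl gives a 1.0-fold lower number from compound 2 to compound 4 (0.00 log units; within the scatter) and a 1.5-fold higher number from compound 3 to compound 4 (0.17 log units; within the scatter) and a 1.3-fold higher number from compound 1 to compound 4 (0.12 log units; within the scatter) in this assay alike. The position has thus now taken a five-membered aromatic ring with a sulfur atom, as well as six-membered rings of carbon only, with no step beyond the scatter. No evidence is available to account for how closely these numbers agree. The compounds shown leave open whether a basic amine on the ring, a carboxylic acid, or a saturated piperidine ring in its place would move the number beyond the scatter.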